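The source may hold more compounds than are shown below. What is called first, only, known or untested is meant among the compounds shown, and "the series" means these compounds.

Values in a functional assay on Huh-5-2 cells (Homo sapiens), read by MTT assay; on this read-out lower numbers stand for higher toxicity in this test and higher numbers for lower toxicity in this test:
- compound 1 `NC(=O)c1ccc(-c2ccc(Cl)cc2COc2ccc(-c3nc4cc(C(=O)O)ccc4n3C3CCCCC3)cc2)cc1`: > 50000 nM (a limit of the assay)
- compound 2 `O=C(O)c1ccc2c(c1)nc(-c1ccc(OCc3cc(Cl)ccc3-c3cccc(Cl)c3)cc1)n2C1CCCCC1`: 32000 nM
- compound 3 `O=C(O)c1ccc2c(c1)nc(-c1ccc(OCc3ccccc3-c3ccc(Cl)cc3)cc1)n2C1CCCCC1`: 25000 nM

Compound 3 stands at 25000 nM, and compound 2 at 32000 nM lies within the scatter of it. Compound 1 gives > 50000 nM, which is a limit and not a number.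

Compound 4 `CN(C)S(=O)(=O)c1ccc(-c2ccc(Cl)cc2)c(COc2ccc(-c3nc4cc(C(=O)O)ccc4n3C3CCCCC3)cc2)c1` is the next compound to be read in this assay. It carries dimethylsulfamoyl in place of hydrogen on an aromatic carbon of compound 3, meta to a large group and para to a 4-chlorophenyl group: dimethylsulfamoyl in place of hydrogen on an aromatic carbon.

For the measured compounds named here, only one measured step is available, an at least 1.5-fold lower number from compound 1 to compound 2 (0.19 log units; that floor lies within the scatter). It exchanges a different group from the one changed here, so it bears on this change only indirectly, and it shows no change beyond the scatter. Going by the values given here, no measured step adds a substituent at this place. The expectation therefore starts from compound 3 at 25000 nM, with no shift in either direction beyond the scatter. The expected change is a 1.3-fold higher number from compound 3 to compound 4 (0.11 log units; within the scatter). Compound 4 may also be reported only as a limit, since the series already holds (the limit of > 50000 nM in this assay, at which 1 of the 3 values shown sits).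

For compound 4 the estimated value is 32000 nM, with an expected range of 14000 nM to 60000 nM.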

Compound 4, half-maximal cytotoxic concentration: 26000 nM
The estimate for compound 4 lay 1.2-fold (0.09 log units) above the measured number, within the range that was stated.
By their numbers in this assay, from the lowest: compounds 3, 4 and 2 (each within the scatter of the next). At a limit, above all of these: compound 1.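

Dimethylsulfamoyl in place of hydrogen, on the aromatic carbon meta to a large group and para to a 4-chlorophenyl group, gives in this assay a 1.0-fold higher number from compound 3 to compound 4 (0.02 log units; within the scatter). For the compounds shown here, this is the first measured step that adds a substituent at this place, and it shows that a group of 6 heavy atoms, with no ring and no net charge, can enter here without moving this read-out beyond the scatter. Compound 4 also reads as a number and not as a limit, so compound 1 remains the only compound shown at the limit of this assay:
the limit of > 50000 nM in this assay, at which 1 of the 4 values shown sits.

One substituent at one carbon does not establish that the read-out stays flat at this position in general, and an amine, a carboxylic acid or a longer alkyl chain at the same carbon would test how far that holds. On these data alone, it also remains open whether dimethylsulfamoyl at this place would give the same reading in the background of compound 2, where the other chlorine substitution differs.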